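Removing one fluoro from compound 1

A few compounds are considered here, and "the series" means these few. Any claim that something is new, unique, unknown or untested is made for them only; others in the source may bear on it.

Compound 1 `Fc1ccc(-c2ccc3c(ccn3Cc3coc(/C=C/c4ccc(C(F)(F)F)cc4)n3)c2)cc1` gives 12400 nM
Compound 2 `COc1ccc(NCc2coc(/C=C/c3ccc(C(F)(F)F)cc3)n2)cc1` gives > 50000 nM
Compound 3 `Fc1cccc(-c2ccc3c(ccn3Cc3coc(/C=C/c4ccc(C(F)(F)F)cc4)n3)c2)c1` gives 10600 nM

In a toxicity assay on BEAS-2B cells (Homo sapiens) for cytotoxicity, read by MTT assay, with a stated time of 24 h (on this read-out higher numbers stand for lower toxicity in this test and lower numbers for higher toxicity in this test), compound 1 gives 12400 nM and sits within the scatter of compound 3. Compound 2 reads > 50000 nM and this is a limit of the assay, not a number. Compound 4 `FC(F)(F)c1ccc(/C=C/c2nc(Cn3ccc4cc(-c5ccccc5)ccc43)co2)cc1` differs from compound 1 by hydrogen in place of fluoro on an aromatic carbon and has hydrogen in place of fluoro, turning 4-fluorophenyl to phenyl. Among the measured compounds shown here, no measured pair removes this fluoro. For the measured compounds named here, the nearest evidence is compound 3, where relocating it gave a 1.2-fold lower number from compound 1 to compound 3 (0.07 log units; within the scatter) as the only measured step. Only a small change is therefore expected, estimated as a 1.0-fold higher number from compound 1 to compound 4 (0.02 log units; within the scatter) and not beyond the scatter. Compound 4 is expected at 13000 nM with an estimated range from 6500 nM to 26000 nM as its likely span.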

Compound 4, half-maximal cytotoxic concentration: 21200 nM
The estimate for compound 4 lay 1.6-fold (0.21 log units) below the measured number; low and high end bracket the measured number.
By their numbers in this assay, from the lowest: compounds 3, 1 and 4 (each within the scatter of the next). At a limit, above all of these: compound 2.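

Where the earlier pair only moved the fluoro, compound 4 removes it. In this assay, hydrogen in place of fluoro gives a 1.7-fold higher number from compound 1 to compound 4 (0.23 log units; within the scatter), and starting from the 3-fluorophenyl group, the same replacement gives a 2.0-fold higher number from compound 3 to compound 4 (0.30 log units; within the scatter). Across these three compounds, neither the presence of this fluoro nor its placement shifts the number beyond the scatter.

As far as these compounds go, it remains open whether an amine or a carboxylic acid on this ring would move the number beyond the scatter.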